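Amide Chain Variation on a Shared Core: Growth Inhibition

The compounds below may be only part of what the source reports. "The series", "measured", "known", "first", "only" and "open" are said of these compounds alone.

Four compounds share one core and differ only in the group on the carbonyl carbon. Compound 1 `CC(C)C(=O)N1CCN(c2nnc3nncn3n2)CC1` carries an isopropyl there, and in a functional assay on HL-60 cells (Homo sapiens) for inhibition, read by MTT assay, with a stated time of 72 h (on this read-out higher numbers stand for weaker inhibition and lower numbers for stronger inhibition), compound 1 gives 1610 nM. Compound 2 `CC(C)(C)C(=O)N1CCN(c2nnc3nncn3n2)CC1` differs from compound 1 by methyl in place of hydrogen on a saturated chain carbon bound to a carbonyl carbon and two saturated chain carbons, a change that gave a 1.2-fold lower number from compound 1 to compound 2 (0.07 log units; within the scatter). In this assay compound 2 gives 1380 nM. Compound 3 `CCCCC(=O)N1CCN(c2nnc3nncn3n2)CC1` carries a butyl, and in this assay compound 3 gives 3130 nM. The steps to compound 3 read a 1.9-fold higher number from compound 1 to compound 3 (0.29 log units; within the scatter) and a 2.3-fold higher number from compound 2 to compound 3 (0.36 log units; beyond the scatter).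

Compound 4 `CCCCCC(=O)N1CCN(c2nnc3nncn3n2)CC1` has not yet been measured. It differs from compound 3 by methyl in place of hydrogen on a saturated chain carbon, four bonds along the chain from a carbonyl carbon. This is the same kind of change as that from compound 1 to compound 2, but not the same one: there the methyl entered on a saturated chain carbon bound to a carbonyl carbon and two saturated chain carbons, whereas here it enters on a saturated chain carbon, four bonds along the chain from a carbonyl carbon. The cores of the two pairs differ by butyl in place of isopropyl on a carbonyl carbon.

Because the earlier methyl step gave a 1.2-fold lower number from compound 1 to compound 2 (0.07 log units; within the scatter), and because chain lengthening from compound 1 to compound 3 gave a 1.9-fold higher number from compound 1 to compound 3 (0.29 log units; within the scatter), compound 4 is expected to show a 1.1-fold higher number from compound 3 to compound 4 (0.05 log units; within the scatter). Compound 4 is therefore estimated at 3500 nM, with a likely range from 1500 nM to 8000 nM.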

Compound 4, half-maximal inhibitory concentration: 3610 nM
Estimate against measurement, compound 4: 1.0-fold (0.01 log units) below, and the stated range covers the measured number.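

Set side by side in this assay, the step of a 1.2-fold higher number from compound 3 to compound 4 (0.06 log units; within the scatter) and the earlier methyl step on the core of compound 1 do not differ beyond the scatter: the same change on two cores in this assay, a 1.2-fold lower number (0.07 log units; within the scatter) from compound 1 to compound 2 and a 1.2-fold higher number (0.06 log units; within the scatter) from compound 3 to compound 4, 1.3-fold (0.13 log units) apart, within the scatter of two such steps

Within this pair of cores, then, methyl in place of hydrogen moved the number by no more than the scatter on either core, although the methyl entered at different places: on a saturated chain carbon bound to a carbonyl carbon and two saturated chain carbons in one pair, and four bonds along the chain from a carbonyl carbon in the other. This does not show that the change is transferable in general, since two small steps show only that neither had a detectable effect here, whereas the modest gaps for compound 4, a 2.2-fold higher number from compound 1 to compound 4 (0.35 log units; beyond the scatter) and a 2.6-fold higher number from compound 2 to compound 4 (0.42 log units; beyond the scatter), involve replacing the whole group on the carbonyl carbon and say nothing about a methyl step alone.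

The compounds shown leave open whether a longer chain than pentyl would stay close to compound 4 in this read-out. They also leave open how a phenyl ring, an amine or a carboxylic acid on the chain would behave on the shared core.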